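A few compounds are considered here, and "the series" means these few. Any claim that something is new, unique, unknown or untested is made for them only; others in the source may bear on it.

Three hydrazone analogues sharing one core were tested in a functional assay on the whole organism for inhibition, with Rattus norvegicus as the target, read by paw edema, with a stated time of 1 h, at a dose of 50 mg/kg; a lower number here means less inhibition, a higher number more inhibition at the dose given (going by the name of the read-out). Compound 1 `CC(=O)c1c(NNc2ccccc2)cc(C)oc1=O` gives 59.5%, compound 2 `CC(=O)c1c(NNc2ccc(Cl)cc2)cc(C)oc1=O` gives 54.4%, and compound 3 `COc1ccc(NNc2cc(C)oc(=O)c2C(C)=O)cc1` gives 50%. Compound 3 holds the smallest of the three numbers, yet the steps of a number 4.4 percentage points lower from compound 2 to compound 3 (within the scatter) and a number 9.5 percentage points lower from compound 1 to compound 3 (within the scatter) show that the three values are not separated beyond the scatter.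

Compound 4 `CC(=O)c1c(NNc2ccc([N+](=O)[O-])cc2)cc(C)oc1=O` is not yet measured. It differs from compound 3 in one place: nitro in place of methoxy on an aromatic carbon.

The measured steps that bear on this change are those at the same ring position: a number 5.1 percentage points lower from compound 1 to compound 2 (within the scatter), a number 9.5 percentage points lower from compound 1 to compound 3 (within the scatter) and a number 4.4 percentage points lower from compound 2 to compound 3 (within the scatter). Each swap at this position left this assay essentially unchanged. No nitro group has been tested here, so the expectation rests on these three steps alone, and the step expected for compound 4 is a number 2 percentage points higher from compound 3 to compound 4 (within the scatter), nothing beyond the scatter.

Compound 4 is therefore estimated at 52%, within a range from 38% to 66%.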

Compound 4, a percentage reported as inhibition, in the whole organism at one dose (the size of the read-out at that dose, not a potency): 53.2%
Beside the measured number, compound 4's estimate is 1.2 percentage points below it, within the range that was stated.
By their numbers in this assay, from the lowest: compounds 3, 4, 2 and 1 (each within the scatter of the next).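

In this assay the nitro group does not set compound 4 apart from any of the other three compounds: the step is a number 3.2 percentage points higher from compound 3 to compound 4 (within the scatter) against methoxy, a number 1.2 percentage points lower from compound 2 to compound 4 (within the scatter) against chloro and a number 6.3 percentage points lower from compound 1 to compound 4 (within the scatter) against hydrogen. The earlier compounds shown here held no nitro group, and this result extends the finding at this aromatic carbon, para to a large group, to four different substituents whose numbers all lie within the scatter of one another. Nothing measured here speaks to why the read-out stays so flat across these swaps.

Going by these compounds, what an amine, a carboxylic acid or a longer chain would do at this position remains open. So does the effect of any change on the shared core, and because each number comes from a single dose at a single time, any difference in potency among these compounds also remains unknown.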